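The source may report more compounds than this note shows. Statements on the series, on what has been measured and on what is new or still open speak of the compounds shown alone.

Measured compounds and values:

- compound 1 `CN(C)CCn1cnnc1-c1cc(Oc2ccc(NC(=O)N/N=C/c3c[nH]c4ccccc34)cc2F)ccn1`, a functional assay on A549 cells (Homo sapiens) for cytotoxicity, read by MTT assay, with a stated time of 72 h; on this read-out lower numbers stand for stronger inhibition and higher numbers for weaker inhibition: 820 nM
- compound 2 `COc1ccc(/C=N/NC(=O)Nc2ccc(Oc3ccnc(-c4nncn4CCN(C)C)c3)c(F)c2)c(OC)c1`, this assay: 2820 nM
- compound 3 `CN(C)CCn1cnnc1-c1cc(Oc2ccc(NC(=O)N/N=C/c3ccc(Cl)cc3)cc2F)ccn1`, this assay: 780 nM

Compound 2 stands at the highest number of the three: the steps to compound 1 and to compound 3 are both beyond the scatter, so it is the weakest of this set in this assay. Compound 1 and compound 3 sit within the scatter of each other, as a 1.1-fold lower number from compound 1 to compound 3 (0.02 log units; within the scatter) shows.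

Compound 4 `CN(C)CCn1cnnc1-c1cc(Oc2ccc(NC(=O)N/N=C/c3ccc(O)c(F)c3)cc2F)ccn1` is not yet measured. It differs from compound 2 by 3-fluoro-4-hydroxyphenyl in place of 2,4-dimethoxyphenyl on a carbon with a double bond to nitrogen.

Among the compounds with values here, two measured steps bear on this. Replacing the 2,4-dimethoxyphenyl of compound 2 by 4-chlorophenyl gave a 3.6-fold lower number from compound 2 to compound 3 (0.56 log units; beyond the scatter), and going the other way from 1H-indol-3-yl to 2,4-dimethoxyphenyl gave a 3.4-fold higher number from compound 1 to compound 2 (0.54 log units; beyond the scatter). Both replacements of the 2,4-dimethoxyphenyl group lowered the number by a modest, beyond-scatter amount. Within the data shown here, compound 4 carries a different six-membered carbon ring at the same place, so a modest drop from compound 2 is expected, though no measured compound shows the 3-fluoro-4-hydroxyphenyl group itself. The expected step is a 2.6-fold lower number from compound 2 to compound 4 (0.41 log units; beyond the scatter). Compound 4 is therefore estimated at 1100 nM, with a range from 400 nM to 3000 nM.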

Compound 4, half-maximal inhibitory concentration: 13400 nM
Beside the measured number, compound 4's estimate is 12-fold (1.09 log units) below it; measured number above the stated range.
By their numbers in this assay, from the lowest: compounds 3 and 1 (each within the scatter of the next); then compound 2; then compound 4.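

In this assay, the carbon with a double bond to nitrogen no longer tolerates every aromatic ring tried: 3-fluoro-4-hydroxyphenyl in place of 2,4-dimethoxyphenyl gives (a 4.8-fold higher number from compound 2 to compound 4 (0.68 log units; beyond the scatter)), the reverse of the drop seen with the other two groups. Within the data shown here, the gap is larger against the two lowest compounds (a 17-fold higher number from compound 3 to compound 4 (1.24 log units; beyond the scatter); a 16-fold higher number from compound 1 to compound 4 (1.21 log units; beyond the scatter)), so compound 2 no longer marks the top of the range at this position, and the range is much wider than the earlier compounds suggested. No measurement shown accounts for the rise.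

The compounds shown do not separate the hydroxyl from the fluorine in 3-fluoro-4-hydroxyphenyl, as both enter together. A 4-hydroxyphenyl without the fluorine, or a 3-fluoro-4-methoxyphenyl with the hydroxyl capped, would divide the two.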